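Ethynyl in place of iodo on the shared core

This account rests on a few compounds, and the source may have more. Where it says the series, first, only, none or still open, it means among the compounds named here.

Compound 3 `COc1ncnc2c1c(I)cn2[C@@H]1O[C@H](CO)[C@@H](O)[C@H]1O` stands only at a limit. In a functional assay on HCT-116 cells (Homo sapiens), read by MTT assay, with a stated time of 72 h (a higher number here means a weaker inhibitor, a lower number a stronger inhibitor), compound 3 gives > 20000 nM, which is a limit of the assay and not a number. The two other measured compounds stand at the same place. Compound 1 `COc1nc(N)nc2c1c(-c1cc3ccccc3o1)cn2[C@@H]1O[C@H](CO)[C@@H](O)[C@H]1O` in this assay gives > 20000 nM, a limit. Compound 2 `Nc1nc(N)c2c(-c3cc4ccccc4o3)cn([C@@H]3O[C@H](CO)[C@@H](O)[C@H]3O)c2n1` in this assay gives > 20000 nM, again a limit. Going by the values given here, the single step measured in one place, a step that the two limits leave unreadable from compound 1 to compound 2, therefore has no readable size. Among the compounds with values here, the whole body of evidence on the measured steps is the limit of > 20000 nM in this assay, at which 3 of the 3 values shown sit, so no step of any size is established.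

Compound 4 `C#Cc1cn([C@@H]2O[C@H](CO)[C@@H](O)[C@H]2O)c2ncnc(OC)c12`, not yet measured, differs from compound 3 in one place: ethynyl in place of iodo on an aromatic carbon. Within the data shown here, no measured step bears on this change; nothing shows what an ethynyl group does, and the three values give no number to move from. With every measured compound at the limit, compound 4 is expected to sit there too, at an estimated 20000 nM with a range from 8000 nM to 50000 nM. The step of a number no higher from compound 3 to compound 4 (the limit leaves the size open) is accordingly expected to be none beyond the scatter, and a further limit rather than a number is the likelier report.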

Compound 4, half-maximal inhibitory concentration: 4060 nM
The estimate for compound 4 lay 4.9-fold (0.69 log units) above the measured number; the whole stated range lies above it.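

In this assay, going by these compounds alone, ethynyl in place of iodo on the aromatic carbon gives an at least 4.9-fold lower number from compound 3 to compound 4 (0.69 log units; beyond the scatter), the first step with a readable direction. Compound 4 is the only compound shown with a number and not a limit, so a change at this place, two ring bonds from the ring nitrogen, can register in this assay. The size of the step remains a minimum, as compound 3 stands at a limit, and the other compounds have not moved from that limit: the limit of > 20000 nM in this assay, at which 3 of the 4 values shown sit.

On these data alone, it remains open whether this number is particular to ethynyl or would also appear with another small group at this place, such as methyl, vinyl or nitrile, or with a longer chain ending in a triple bond. As far as these compounds go, the step from compound 1 to compound 2 cannot be read, so it is also open whether amino in place of methoxy on the shared core would change the number seen with ethynyl.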